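The source may hold more compounds than are shown below. What is called first, only, known or untested is meant among the compounds shown, and "the series" means these compounds.

Measured compounds:
- Compound 1 `CCC[C@H](C(=O)Nc1nccs1)c1ccc(Cl)cc1` gives 5500 nM in a functional assay on CHO cells for agonist activity at Free fatty acid receptor 2 (Homo sapiens), read by cAMP accumulation; a higher number here means a weaker inhibitor, a lower number a stronger inhibitor
- Compound 2 `CC(C)C[C@H](C(=O)Nc1nccs1)c1ccc(Cl)cc1` gives 600 nM in this assay

Compound 2 stands at the lower of the two numbers in this assay; the nearest point is compound 1, and the step of a 9.2-fold lower number from compound 1 to compound 2 (0.96 log units; beyond the scatter) lies beyond the scatter. Within the data shown here, only this single step is known so far.

Compound 3 `COCC[C@H](C(=O)Nc1nccs1)c1ccc(Cl)cc1` is the next point: the change is methoxymethyl in place of isopropyl on a saturated chain carbon, two bonds along the chain from an aromatic carbon and a carbonyl carbon. Among the measured compounds shown here, the one measured step bears on it only in part. For the measured compounds named here, the step of a 9.2-fold lower number from compound 1 to compound 2 (0.96 log units; beyond the scatter) shows that the branch methyl on the chain of compound 2 went with a lower number; compound 3 gives up that branch and takes in the oxygen instead, for which no measured pair exists. The expectation is therefore weighed toward losing part of what compound 2 gained, without a firm anchor for the oxygen. The step from compound 2 to compound 3 is expected to read a 3.3-fold higher number from compound 2 to compound 3 (0.52 log units; beyond the scatter), an upward move of moderate size. Compound 3 is estimated at 2000 nM, in the range 600 nM to 7000 nM.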

Compound 3, half-maximal inhibitory concentration: 170000 nM
Compound 3: middle estimate off by 85-fold (1.93 log units), on the low side; measured number above the stated range.
By their numbers in this assay, from the lowest: compound 2; then compound 1; then compound 3.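

Working notes on the chain position: in this assay, this saturated chain carbon, two bonds along the chain from an aromatic carbon and a carbonyl carbon, does not accept methoxymethyl as an equivalent of isopropyl, although both groups hold 3 heavy atoms and differ in the count by one oxygen for one carbon and by one hydrogen-bond acceptor, giving a 280-fold higher number from compound 2 to compound 3 (2.45 log units; beyond the scatter). Loss of the branch alone does not account for this result, since the unbranched pair also moves up when methoxy stands in place of methyl, giving a 31-fold higher number from compound 1 to compound 3 (1.49 log units; beyond the scatter), so compound 3 stands beyond both all-carbon chains in this series. No supporting measurement bears on why the oxygen-containing chain reads so much higher.

From the compounds shown here alone, with one oxygen-containing chain in hand, it remains open whether the outcome follows the ether oxygen itself or its place along the chain, and a hydroxyl, an amine or a plain ethyl or n-pentyl chain at this carbon would help separate those readings. Going by these compounds, the all-carbon trend also rests on a single step, a 9.2-fold lower number from compound 1 to compound 2 (0.96 log units; beyond the scatter), so how far further branching or a longer chain would carry it remains unknown.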